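This account rests on a few compounds, and the source may have more. Where it says the series, first, only, none or still open, it means among the compounds named here.

Compound 1 `CCC1(Cc2ccccc2)OS(=O)(=O)C=C1OCc1ccc(OC)cc1` is examined in an ADME assay on HEL cells (Homo sapiens) for cytotoxicity, with a stated time of 3 days; a lower number here means that less compound is tolerated, a higher number that more compound is tolerated. In this assay compound 1 gives >= 200000 nM, which is a limit of the assay rather than a number; it stands at the limit of >= 200000 nM in this assay, at which 1 of the 2 values shown sits. Compound 2 `C=CCOC1=CS(=O)(=O)OC1(CC)Cc1ccccc1` gives 80000 nM in this assay. Going by the values given here, the single measured step, an at least 2.5-fold lower number from compound 1 to compound 2 (0.39 log units; beyond the scatter), alters a different part of the molecule. Compound 3 `CCC1(Cc2ccccc2)OS(=O)(=O)C=C1OCc1ccc(C(F)(F)F)cc1` differs from compound 1 by trifluoromethyl in place of methoxy on an aromatic carbon. Among the compounds with values here, no measured step speaks to this particular change. The expected step is an at least 1.3-fold lower number from compound 1 to compound 3 (0.12 log units; that floor lies within the scatter) in this assay, near or within the scatter. Compound 3 is estimated at 150000 nM, with a range from 40000 nM to 200000 nM.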

Compound 3, minimum cytotoxic concentration: >= 16000 nM
Compound 3: a limit, no number; the forecaster's own chance of this, stated with the estimate: 50%; the middle value lies beyond the limit too.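

Going by these compounds alone, compound 1 and compound 3 are both reported only as limits in this assay, so no step between them can be read. The compounds shown leave open whether trifluoromethyl in place of methoxy changes the tolerated concentration at all, and in which direction.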